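From a Bromophenyl to a Methoxyphenyl Hydrazide

The source may hold more compounds than are shown below. What is called first, only, known or untested is meant among the compounds shown, and "the series" means these compounds.

Compound 1 `C/C(=N\NC(=O)COc1cccc2ccccc12)c1ccc(C#N)cc1Br` gives 12.1 ug/mL in an ADME assay on MT4 cells (Homo sapiens) for cytotoxicity, read by MTT assay, with a stated time of 4 days; a lower number here means that less compound is tolerated, a higher number that more compound is tolerated. Compound 2 `O=C(COc1cccc2ccccc12)N/N=C/c1ccccc1Br` gives 11.4 ug/mL. Compound 3 `C/C(=N\NC(=O)COc1cccc2ccccc12)c1ccc(Cl)cc1` gives 4.07 ug/mL.

Compound 2 holds the second highest of the three numbers; its value and that of compound 1 lie within the scatter of each other, while compound 3 sits below compound 2 by a gap beyond the scatter. Compound 4 `COc1ccc(/C=N/NC(=O)COc2cccc3ccccc23)cc1` differs from compound 2 in one place: 4-methoxyphenyl in place of 2-bromophenyl on a carbon with a double bond to nitrogen. Within the data shown here, the only measured step that resembles this change, a ring bearing a bromine at position 2 giving way to a ring substituted at position 4, is a 3.0-fold lower number from compound 1 to compound 3 (0.47 log units; beyond the scatter), a modest drop. A similar modest drop is therefore expected here, a 1.8-fold lower number from compound 2 to compound 4 (0.24 log units; within the scatter). Compound 4 is estimated at 6.5 ug/mL, within a range from 3 ug/mL to 16 ug/mL.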

Compound 4, half-maximal cytotoxic concentration: 76.9 ug/mL
Beside the measured number, compound 4's estimate is 12-fold (1.07 log units) below it; measured number above the stated range.
By their numbers in this assay, from the lowest: compound 3; then compounds 2 and 1 (each within the scatter of the next); then compound 4.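

In this assay this position can move the number strongly upward: a 6.7-fold higher number from compound 2 to compound 4 (0.83 log units; beyond the scatter), so more compound is tolerated with 4-methoxyphenyl than with 2-bromophenyl. The earlier change away from a bromine-bearing ring ran the other way, with a 3.0-fold lower number from compound 1 to compound 3 (0.47 log units; beyond the scatter), so losing the bromine does not set the direction on its own. No measurement here explains the rise.

Compound 2 and compound 4 differ in both the group and where it sits on the ring, and these compounds do not separate the two. Going by these compounds, how an amine or a carboxylic acid on that ring would behave also remains open.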